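The source may hold more compounds than are shown below. What is called first, only, known or untested is meant among the compounds shown, and "the series" means these compounds.

Working notes on the series. Compound 1 `O=C(Nc1ccccc1)c1ccc(/N=N\c2c[nH]c3ccccc23)cc1` gives 103000 nM in a functional assay on HCT-116 cells (Homo sapiens) for inhibition, read by MTT assay, with a stated time of 72 h; a lower number here means a stronger inhibitor, a higher number a weaker inhibitor. Among the measured compounds shown here, compound 2 `Cc1cccc(NC(=O)c2ccc(/N=N\c3c[nH]c4ccccc34)cc2)c1C` gives 272000 nM in this assay, the highest of the two numbers so far; the only measured step, a 2.6-fold higher number from compound 1 to compound 2 (0.42 log units; beyond the scatter), puts compound 2 beyond the scatter from compound 1. Compound 3 `O=C(Nc1ccccc1Cl)c1ccc(/N=N\c2c[nH]c3ccccc23)cc1` differs from compound 2 by 2-chlorophenyl in place of 2,3-dimethylphenyl on an amide-type nitrogen. For the measured compounds named here, only the step from compound 1 to compound 2 bears on this change, and it was modest. The step from compound 2 to compound 3 is expected to be small, around a 1.8-fold lower number from compound 2 to compound 3 (0.26 log units; within the scatter), back toward compound 1. Compound 3 is estimated at 150000 nM, between 60000 nM and 400000 nM.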

Compound 3, half-maximal inhibitory concentration: 120000 nM
Estimate against measurement, compound 3: 1.3-fold (0.10 log units) above; measured number inside the range.
By their numbers in this assay, from the lowest: compounds 1 and 3 (each within the scatter of the next); then compound 2.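

In this assay, the change to 2-chlorophenyl on the amide-type nitrogen gives a 2.3-fold lower number from compound 2 to compound 3 (0.36 log units; beyond the scatter), whereas chloro in place of hydrogen on an aromatic carbon gives a 1.2-fold higher number from compound 1 to compound 3 (0.07 log units; within the scatter), a step within the scatter. Among these three compounds, only the 2,3-dimethylphenyl group of compound 2 stands apart, and one chloro on the phenyl ring shifts the number by no more than the scatter. Nothing available explains either step.

Going by these compounds, whether a single methyl behaves like chloro or like 2,3-dimethylphenyl remains open. On these data alone, the effect of an amine or a carboxylic acid on that ring also remains open.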